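Swapping trifluoromethyl for chloro on a second core

A few compounds are considered here, and "the series" means these few. Any claim that something is new, unique, unknown or untested is made for them only; others in the source may bear on it.

Measured so far:
compound 1, `O=C(Nc1cccc(-n2cc(-c3ccncc3)c(-c3cc(O)cc(Cl)c3)n2)c1)Nc1ccc(Cl)c(C(F)(F)F)c1`, 2.08%
compound 2, `O=C(Nc1cccc(-n2cc(-c3ccncc3)c(-c3cc(O)cc(Cl)c3)n2)c1)Nc1ccc(Cl)c(Cl)c1`, -84.7%
compound 3, `COc1cc(Cl)cc(-c2nn(-c3cccc(NC(=O)Nc4ccc(Cl)c(C(F)(F)F)c4)c3)cc2-c2ccncc2)c1`, 4.81%

In a functional assay on LOX IMVI cells (Homo sapiens) for inhibition, read by sulforhodamine B assay, with a stated time of 48 h, tested at 10 uM (a lower number here means a stronger effect, a higher number a weaker effect of the compound at the concentration tested), compound 1 gives 2.08%. Compound 2 differs from compound 1 by chloro in place of trifluoromethyl on an aromatic carbon, and this change made a number 86.8 percentage points lower from compound 1 to compound 2 (beyond the scatter). Compound 3 differs from compound 1 by methyl in place of hydrogen on an oxygen on an aromatic ring, and here a number 2.7 percentage points higher from compound 1 to compound 3 (within the scatter), so the two cores do not stand apart in this assay by more than the usual scatter.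

Compound 4, `COc1cc(Cl)cc(-c2nn(-c3cccc(NC(=O)Nc4ccc(Cl)c(Cl)c4)c3)cc2-c2ccncc2)c1`, has not yet been measured. It differs from compound 3 by chloro in place of trifluoromethyl on an aromatic carbon. This is the same change as that from compound 1 to compound 2, at a place described in the same words, made on the core of compound 3 rather than the core of compound 1. Resting on the single earlier instance, compound 4 is expected to show a step of similar size, a number 69.8 percentage points lower from compound 3 to compound 4 (beyond the scatter), set beside a number 86.8 percentage points lower from compound 1 to compound 2 (beyond the scatter). The expected value for compound 4 is -65%, within -105% to 5%.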

Compound 4, a percentage reported as activity, at one concentration (the size of the read-out at that concentration, not a potency): 9.24%
Estimate against measurement, compound 4: 74.2 percentage points below, and the stated range ends below it.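

In this assay, chloro in place of trifluoromethyl gave a number 4.4 percentage points higher from compound 3 to compound 4 (within the scatter), so the large step seen on the core of compound 1 did not carry over to the core of compound 3: the same change on two cores in this assay, a number 86.8 percentage points lower (beyond the scatter) from compound 1 to compound 2 and a number 4.4 percentage points higher (within the scatter) from compound 3 to compound 4, 91.2 percentage points apart, beyond the scatter of two such steps

Read along the other edge of the same four compounds, methyl in place of hydrogen on the oxygen gave a number 93.9 percentage points higher from compound 2 to compound 4 (beyond the scatter), while the same change with trifluoromethyl present gave a much smaller step: the same change on two cores in this assay, a number 2.7 percentage points higher (within the scatter) from compound 1 to compound 3 and a number 93.9 percentage points higher (beyond the scatter) from compound 2 to compound 4, 91.2 percentage points apart, beyond the scatter of two such steps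

The two changes therefore do not add independently in this series, and the large effect rests on compound 2 alone, but a single set of four compounds does not show why this is so or whether it would hold for any other pair of cores.

The compounds shown leave open whether the large step needs the free hydroxyl, which an ethoxy group or an amine in its place could test, and whether it also appears with bromo or methyl in place of the entering chloro. They also leave open whether the pattern holds at other concentrations or in other cell lines.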